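Does tert-butyl keep compound 4 at the limit?

The source may hold more compounds than are shown below. What is called first, only, known or untested is meant among the compounds shown, and "the series" means these compounds.

Of the compounds shown here, three have been measured so far in an ADME assay on H9c2 cells (Rattus norvegicus) for cytotoxicity (a lower number here means a stronger inhibitor, a higher number a weaker inhibitor), and they read as follows.
Compound 1 `CCOc1ccc2nc(NC(=O)C3CC3)sc2c1` gives > 50000 nM as a limit
Compound 2 `O=C(Nc1nc2ccc(F)cc2s1)C1CC1` gives > 50000 nM as a limit
Compound 3 `CCCC(=O)Nc1nc2ccc(Cl)cc2s1` gives > 50000 nM as a limit

Each of these readings is a limit and not a number. Compound 3 therefore has no numerical value that could place it relative to the other two. Within the data shown here, the series so far shows only the limit of > 50000 nM in this assay, at which 3 of the 3 values shown sit, and no measured number.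

Compound 4 `CC(C)(C)C(=O)Nc1nc2ccc(Cl)cc2s1` differs from compound 3 in a single group (tert-butyl in place of propyl on a carbonyl carbon), with tert-butyl in place of propyl on a carbonyl carbon. Among the measured compounds shown here, the one measured step (a step that the two limits leave unreadable from compound 1 to compound 2) has no readable size. It also concerns an aromatic carbon rather than the carbonyl carbon, so it offers no size to carry over.

In this assay, for the measured compounds named here, no step of a definite size or direction is expected, and compound 4 is expected to report the same limit. That expectation rests on compound 3 at > 50000 nM as a limit. The expected step (a step that the limit leaves unreadable from compound 3 to compound 4) is only an estimate. Compound 4 is estimated at 60000 nM within an expected range of 25000 nM to 150000 nM until it is measured.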

Compound 4, half-maximal inhibitory concentration: > 50000 nM
Compound 4 was reported as a limit (the forecaster's own chance of this, stated with the estimate: 80%); the middle value lies beyond the limit too.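

In this assay compound 3 and compound 4 are both reported only as limits, so no step can be read for tert-butyl in place of propyl on a carbonyl carbon. The compounds shown leave open what half-maximal inhibitory concentration any of them has and whether any change among them alters it, since the series offers only one reading: the limit of > 50000 nM in this assay, at which 4 of the 4 values shown sit.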